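Dihydrofuran carboxamides and acids: no cytotoxic signal yet

This account rests on a few compounds, and the source may have more. Where it says the series, first, only, none or still open, it means among the compounds named here.

The series rests on a shared dihydrofuran core carrying a vinyl group, an aryl group on a saturated ring carbon and a carbonyl substituent on the double-bonded ring carbon. Compound 1 `C=CC1=C(C(=O)NCc2ccccc2)C(c2ccc(OC)cc2)OC1` bears the benzylamide and the 4-methoxyphenyl group. In a functional assay on QGY7701 cells (Homo sapiens) for cytotoxicity, read by MTT assay, with a stated time of 24 h (on this read-out lower numbers stand for stronger inhibition and higher numbers for weaker inhibition), compound 1 gives only a limit, > 100000 nM. Compound 2 `C=CC1=C(C(=O)O)C(c2ccc(OC)cc2)OC1` is the corresponding acid, differing by hydroxy in place of benzylamino on a carbonyl carbon. In this assay compound 2 also gives only a limit, > 100000 nM. Compound 3 `C=CC1=C(C(=O)NCc2ccccc2)C(c2ccc(Cl)c(Cl)c2)OC1` keeps the benzylamide but changes the aryl group, (3,4-dichlorophenyl in place of 4-methoxyphenyl on a saturated ring carbon). In this assay compound 3 likewise gives only a limit, > 100000 nM.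

The step that the two limits leave unreadable from compound 1 to compound 2 and the step that the two limits leave unreadable from compound 1 to compound 3 cannot be sized, because of the limit of > 100000 nM in this assay, at which 3 of the 3 values shown sit. Compound 4 `C=CC1=C(C(=O)O)C(c2ccc(Cl)c(Cl)c2)OC1` has not yet been measured; it differs from compound 3 by hydroxy in place of benzylamino on a carbonyl carbon. This is the same change as that from compound 1 to compound 2, made on a core that differs by the aryl group as described, and the place of the change is worded identically in both cases.

Among the measured compounds shown here, because the only comparable change, a step that the two limits leave unreadable from compound 1 to compound 2, gave no readable step and because of the limit of > 100000 nM in this assay, at which 3 of the 3 values shown sit, a step that the limit leaves unreadable from compound 3 to compound 4 is expected from compound 3 to compound 4, with a high chance that again only a limit is reported. For compound 4 in this assay the estimate is 150000 nM, expected to lie between 50000 nM and 500000 nM.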

Compound 4, half-maximal inhibitory concentration: > 100000 nM
Compound 4: only a limit was reported (the forecaster's own chance of this, stated with the estimate: 85%); the middle value is on the limit's open side.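

In this assay compound 4 gives > 100000 nM, which is a limit and not a number. No step can be read from compound 3 to compound 4, because both values are limits: the limit of > 100000 nM in this assay, at which 4 of the 4 values shown sit.

The compounds shown leave open whether any change on the shared core gives a readable value in this assay, and how the benzylamides and acids truly compare.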